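Halogen Swap on a Carbamate Series: Pancreatic Cell Growth

The source may report more compounds than this note shows. Statements on the series, on what has been measured and on what is new or still open speak of the compounds shown alone.

Compound 1, `CC(C)=CCC1Cc2c(OC(=O)Nc3ccc(F)cc3)cc(=O)n(CCCO)c2CC1(C)C`: 0%
Compound 2, `CC(C)=CCC1Cc2c(OC(=O)Nc3ccc(F)c(Cl)c3)cc(=O)n(CCCO)c2CC1(C)C`: 0%

Both numbers come from a functional assay on PANC-1 cells (Homo sapiens) for inhibition, read by MTT assay, with a stated time of 24 h, tested at 10 uM; on this read-out higher numbers stand for more inhibition at the one concentration tested (going by the name of the read-out) and lower numbers for less inhibition. In this assay compound 1 gives 0%, and compound 2 gives 0%, so compound 2 stands level with compound 1. Going by the values given here, the single step between them, no change at the digits printed from compound 1 to compound 2 (within the scatter), is chloro in place of hydrogen on an aromatic carbon; adding that halogen to the ring moved nothing beyond the scatter.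

Compound 3, `CC(C)=CCC1Cc2c(OC(=O)Nc3ccc(Cl)c(Cl)c3)cc(=O)n(CCCO)c2CC1(C)C`, is not yet measured. It differs from compound 2 by chloro in place of fluoro on an aromatic carbon. Among the compounds with values here, the only step that bears on this change is the halogen addition from compound 1 to compound 2, which was flat, and the measured values sit at the floor of the read-out. Exchanging one halogen for another on the same ring is therefore expected to give a number 2 percentage points higher from compound 2 to compound 3 (within the scatter), with compound 3 estimated at 2%, within a range of -8% to 12%.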

Compound 3, a percentage reported as inhibition, at one concentration (the size of the read-out at that concentration, not a potency): 1.8%
For compound 3 the middle estimate is 0.2 percentage points above the measured one; the measured number falls inside the stated range.
By their numbers in this assay, from the lowest: compounds 1, 2 and 3 (each within the scatter of the next).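

In this assay, exchanging fluoro for chloro at this position, para to a large group, gives a number 1.8 percentage points higher from compound 2 to compound 3 (within the scatter) and so leaves the read-out essentially unmoved, which extends the flat result from adding a halogen to replacing one. The two ring changes taken together, from 4-fluorophenyl to 3,4-dichlorophenyl on the amide-type nitrogen, give a number 1.8 percentage points higher from compound 1 to compound 3 (within the scatter) and also fail to separate the compounds, so neither the choice of halogen nor the number of halogens shows any effect here. No supporting measurement is available to explain this flat result.

As far as these compounds go, whether an amine, a methoxy group or a carboxylic acid in place of this chloro would change the read-out remains open. Also open is whether any of these compounds would show inhibition at a concentration other than the single one tested.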